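Aryl Swap on the Triazole: Compound 4 Before Measurement

The compounds below may be only part of what the source reports. "The series", "measured", "known", "first", "only" and "open" are said of these compounds alone.

compound 1 `N#CC1=C(N)Oc2c(N)cc3nc4ccccc4nc3c2C12C(=O)N(Cc1cnnn1-c1ccccc1Cl)c1ccccc12` — > 50000 nM
compound 2 `N#CC1=C(N)Oc2c(N)cc3nc4ccccc4nc3c2C12C(=O)N(Cc1cnnn1-c1ccccc1Br)c1ccccc12` — 34200 nM
compound 3 `N#CC1=C(N)Oc2c(N)cc3nc4ccccc4nc3c2C12C(=O)N(Cc1cnnn1-c1cccc(C(F)(F)F)c1)c1ccccc12` — > 50000 nM

Three compounds sharing one core differ only in the aryl group on the triazole nitrogen. In an ADME assay on HUVEC cells (Homo sapiens) for antiproliferative activity, read by MTT assay, with a stated time of 48 h (on this read-out higher numbers stand for weaker inhibition and lower numbers for stronger inhibition), compound 1 gives only a limit, > 50000 nM. Compound 2, with bromo in place of chloro on the aromatic carbon, gives a number in this assay, 34200 nM; the change is an at least 1.4-fold lower number from compound 1 to compound 2 (0.16 log units; that floor lies within the scatter). Compound 3 again gives only a limit, > 50000 nM. Compound 3 therefore stands at the limit of > 50000 nM in this assay, at which 2 of the 3 values shown sit, and its step from compound 2 is an at least 1.4-fold higher number from compound 2 to compound 3 (0.16 log units; that floor lies within the scatter), while a step that the two limits leave unreadable from compound 1 to compound 3.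

Compound 4 `CC(=O)Nc1ccc(-n2nncc2CN2C(=O)C3(C(C#N)=C(N)Oc4c(N)cc5nc6ccccc6nc5c43)c3ccccc32)cc1` carries 4-acetamidophenyl in place of 3-(trifluoromethyl)phenyl on an aromatic nitrogen. Going by the values given here, the measured steps that bear on this change are the aryl swaps from compound 1 to compound 3 and from compound 2 to compound 3, and neither of them is readable as a shift beyond the scatter; the one readable step, from compound 1 to compound 2, also stays within the scatter. On that basis compound 4 is expected to show a number no higher from compound 3 to compound 4 (the limit leaves the size open), that is, no shift beyond the scatter in this assay. Compound 4 is estimated at 50000 nM, with a range from 20000 nM to 120000 nM, and a limit rather than a number is thought likely.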

Compound 4, half-maximal inhibitory concentration: > 50000 nM
Compound 4: a limit, no number (the forecaster's own chance of this, stated with the estimate: 55%); the middle value lies on the limit itself.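

In this assay compound 4 gives > 50000 nM, which is a limit and not a number. Going by these compounds alone, the 4-acetamidophenyl group adds a hydrogen-bond donor and a hydrogen-bond acceptor that the 3-(trifluoromethyl)phenyl group lacks, yet this change on the aromatic nitrogen still produces no readable number, so the limit now spans aryl groups that differ more widely than the earlier compounds did: the limit of > 50000 nM in this assay, at which 3 of the 4 values shown sit. Within the data shown here, the only step that can be read here is an at least 1.4-fold higher number from compound 2 to compound 4 (0.16 log units; that floor lies within the scatter), while the steps to compound 4 from the two other compounds held at the limit cannot be read.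

The compounds shown leave open whether any group at this position gives a number clearly apart from the limit, as compound 2 alone gives a number and its step stays within the scatter. On these data alone, it also remains open whether a carboxylic acid or a dimethylamino group on the phenyl ring, or a longer alkyl chain in place of that ring, would bring a readable value in this assay.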